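The compounds below may be only part of what the source reports. "The series", "measured", "known", "first", "only" and "open" are said of these compounds alone.

In a physicochemical assay for solubility, in phosphate buffer, measured as kinetic solubility, at pH 7.4, tested at 250 uM (a higher number here means a more soluble compound, a lower number a less soluble compound), compound 1 `CCCCCCNc1ccc(C(=O)O)cc1S(N)(=O)=O` gives 238000 nM as its reading. Compound 2 `CCCCCCNc1ccc(C(=O)O)cc1S(=O)(=O)NC` gives 247000 nM and compound 3 `CCCCCCNc1ccc(C(=O)O)cc1S(=O)(=O)N(C)C` gives 243000 nM on the same measure. Compound 3 therefore stands level with compound 1 and compound 2, with its gaps to both lying within the scatter.

The next structure, compound 4 `CN(C)S(=O)(=O)c1cc(C(=O)O)ccc1NCCCC(F)(F)F`, differs from compound 3 by trifluoromethyl in place of propyl on a saturated chain carbon, three bonds along the chain from a nitrogen on an aromatic ring on a saturated chain carbon, three bonds along the chain from a nitrogen on an aromatic ring. The same difference can be read as hexyl to 4,4,4-trifluorobutyl.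

Among the compounds with values here, only three measured steps are available, and they bear on this change indirectly. They are a 1.0-fold higher number from compound 1 to compound 2 (0.02 log units; within the scatter) and a 1.0-fold higher number from compound 1 to compound 3 (0.01 log units; within the scatter) and a 1.0-fold lower number from compound 2 to compound 3 (0.01 log units; within the scatter) and all three lie within the scatter. Within the data shown here, each of them concerns the sulfonamide nitrogen, and no measured compound alters the hexyl chain, so the data hold no direct precedent for the new change. With only that flat series to go on, no step beyond the scatter is expected in this assay, and no direction can be assigned. The estimated change is a 1.0-fold lower number from compound 3 to compound 4 (0.01 log units; within the scatter) and it remains an expectation only. For compound 4 the expected value is 238000 nM with an estimated range from 170000 nM to 255000 nM in this measure.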

Compound 4, solubility: 245000 nM
Estimate against measurement, compound 4: 1.0-fold (0.01 log units) below; low and high end bracket the measured number.
By their numbers in this assay, from the lowest: compounds 1, 3, 4 and 2 (each within the scatter of the next).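

In this assay, within the data shown here, the change from propyl to trifluoromethyl on a saturated chain carbon, three bonds along the chain from a nitrogen on an aromatic ring, gives a 1.0-fold higher number from compound 3 to compound 4 (0.00 log units; within the scatter) and so supplies the first measured step on the chain rather than on the sulfonamide nitrogen. Read as hexyl to 4,4,4-trifluorobutyl, this step falls within the scatter, as do the three earlier steps, so among these four compounds neither the chain change nor the changes on the sulfonamide nitrogen separates one reading from another. No available evidence accounts for this result.

Open, from the compounds shown here alone, is whether a longer chain, a shorter chain, or a chain ending in an amine or a hydroxyl group would also stay within the scatter at this position. Also open, going by these compounds, is whether an amide in place of the carboxylic acid would give a step beyond the scatter, since all four readings lie close to the tested concentration and the series does not show how far a reading could move in either direction.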